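The source may hold more compounds than are shown below. What is called first, only, known or untested is meant among the compounds shown, and "the series" means these compounds.

Compound 1, `C=CS(=O)(=O)c1cc(C(F)(F)F)cc(C(F)(F)F)c1`, in an ADME assay for pharmacokinetics, read by LC-MS, in phosphate buffer, with a stated time of 72 h, at pH 7.4, tested at 250 uM (on this read-out higher numbers stand for a longer-lived compound and lower numbers for a shorter-lived compound), gives < 0.017 h, which is a limit of the assay.
Compound 2, `C#Cc1cc(C(F)(F)F)cc(C(F)(F)F)c1`, in this assay gives 5.9 h.
Compound 3, `O=C(CBr)c1cc(C(F)(F)F)cc(C(F)(F)F)c1`, in this assay gives < 0.017 h, again a limit of the assay.

Compound 3 thus stands at the bottom of the shown numbers, with no readable value, because of the limit of < 0.017 h in this assay, at which 2 of the 3 values shown sit. Compound 4, `Fc1cc(C(F)(F)F)cc(C(F)(F)F)c1`, differs from it by fluoro in place of (bromomethyl)carbonyl on an aromatic carbon. Going by the values given here, two measured steps bear on this change: an at least 340-fold lower number from compound 2 to compound 3 (2.54 log units; beyond the scatter) and an at least 340-fold higher number from compound 1 to compound 2 (2.54 log units; beyond the scatter), both large and both turning on the same two groups, while the step that the two limits leave unreadable from compound 1 to compound 3 gives no guidance. Removing the (bromomethyl)carbonyl is therefore expected to bring a large rise, an at least 5800-fold higher number from compound 3 to compound 4 (3.76 log units; beyond the scatter). Compound 4 is estimated to reach 100 h (from 15 h to 700 h), quite possibly reported only as a limit.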

Compound 4, half-life: > 50 h
Compound 4 gave a limit, no number (the forecaster's own chance of this, stated with the estimate: 60%); the middle value is on the limit's open side.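

At this aromatic carbon, fluoro gives the longest-lived compound shown: in this assay compound 4 gives > 50 h, a limit of the assay and not a number. Fluoro in place of (bromomethyl)carbonyl or vinylsulfonyl gives an at least 2900-fold higher number from compound 3 to compound 4 (3.46 log units; beyond the scatter) and an at least 2900-fold higher number from compound 1 to compound 4 (3.46 log units; beyond the scatter). Ethynyl, the only earlier group with a readable half-life, is also surpassed, with an at least 8.4-fold higher number from compound 2 to compound 4 (0.92 log units; beyond the scatter).

On these data alone, the actual half-life of compound 4 remains unknown. Also open, as far as these compounds go, is how an amine or a carboxylic acid would fare on this same aromatic carbon.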